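Acetamido to Benzamido on a Shared Core: Cytotoxicity Outlook

The compounds below may be only part of what the source reports. "The series", "measured", "known", "first", "only" and "open" are said of these compounds alone.

Compound 1 `CC(=O)Nc1c(C)c(C(OC(C)(C)C)C(=O)O)c(-c2ccc(C)c(C)c2)c(C)c1-c1ccc(C)c(C)c1`: 19000 nM
Compound 2 `Cc1ccc(-c2c(C)c(-c3ccc4c(c3)CCO4)c(C(OC(C)(C)C)C(=O)O)c(C)c2NS(C)(=O)=O)cc1C`: 38000 nM

Of the compounds shown here, two have been measured in an ADME assay on MT4 cells (Homo sapiens) for cytotoxicity, read by MTT assay, with a stated time of 4 days; a higher number here means that more compound is tolerated, a lower number that less compound is tolerated. Compound 1 gives 19000 nM, the lowest of the two numbers. Compound 2 gives 38000 nM, and the gap between the two values lies within the usual scatter, so neither compound can be said to be better tolerated than the other.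

Compound 3 `Cc1ccc(-c2c(C)c(-c3ccc(C)c(C)c3)c(C(OC(C)(C)C)C(=O)O)c(C)c2NC(=O)c2ccccc2)cc1C` has not yet been measured in this assay. It differs from compound 1 in one place: phenyl in place of methyl on a carbonyl carbon. Going by the values given here, no step between two measured compounds isolates a change of this kind, so the expectation for compound 3 rests on the two values alone, which sit close together despite differing in several places.

Compound 3 is therefore expected to show a step of a 1.3-fold lower number from compound 1 to compound 3 (0.10 log units; within the scatter) that stays within the scatter, perhaps leaning toward a lower number. Compound 3 is estimated at 15000 nM in this assay, with a range from 6000 nM to 40000 nM.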

Compound 3, half-maximal cytotoxic concentration: 9100 nM
Estimate against measurement, compound 3: 1.6-fold (0.22 log units) above, within the range that was stated.
By their numbers in this assay, from the lowest: compound 3; then compounds 1 and 2 (each within the scatter of the next).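

Phenyl in place of methyl on a carbonyl carbon yields a 2.1-fold lower number from compound 1 to compound 3 (0.32 log units; beyond the scatter) in this assay and this is the first change in the set that can be read in a single place, since the two earlier compounds differ in several places at once. The step is modest but lies beyond the scatter, which shows that the read-out is not indifferent to the group on this carbonyl carbon: with the rest of the shared core unchanged, going from acetamido to benzamido leaves less compound tolerated. No measurement of any property of these compounds bears on this step, and the data offer no explanation for it.

A single pair cannot show whether the step belongs to phenyl itself or would also appear with another group on the same carbonyl carbon, such as a longer chain like propyl, a cyclohexyl ring, or a phenyl ring carrying an amine or a carboxylic acid. On these data alone, it also remains open whether the same change would give a step of similar size on a core that carries other groups elsewhere.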